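The compounds below may be only part of what the source reports. "The series", "measured", "known", "first", "only" and "open" are said of these compounds alone.

Compound 1, `CC[C@@H]1C(=O)N(C)c2cnc(Nc3ccc(C(=O)NC4CCN(C)CC4)cc3OC)nc2N1C1CCCCC1`, gives 4 nM in an assay on isolated protein for inhibition of serine/threonine-protein kinase PLK1 (Homo sapiens), read by Z'-LYTE; on this read-out higher numbers stand for weaker inhibition and lower numbers for stronger inhibition. Compound 2, `CC[C@@H]1C(=O)N(C)c2cnc(Nc3ccc(C(=O)NC4CCN(C)CC4)cc3OC)nc2N1C(C)C`, carries isopropyl in place of cyclohexyl on a nitrogen on an aromatic ring in a ring relative to compound 1, and the step from one to the other is no change at the digits printed from compound 1 to compound 2 (within the scatter); compound 2 gives 4 nM. Compound 3, `COc1cc(C(=O)NC2CCN(C)CC2)ccc1Nc1ncc2c(n1)N(C1CCCCC1)[C@H](C)C(=O)N2C`, differs from compound 1 by hydrogen in place of methyl on a saturated chain carbon bound to a saturated ring carbon, a change that shows up as a 2.2-fold higher number from compound 1 to compound 3 (0.33 log units; beyond the scatter), so that compound 3 gives 8.6 nM. Compound 4, `COc1cc(C(=O)NC2CCN(C)CC2)ccc1Nc1ncc2c(n1)N(C(C)C)[C@H](C)C(=O)N2C`, stands to compound 3 as compound 2 stands to compound 1, through (isopropyl in place of cyclohexyl on a nitrogen on an aromatic ring in a ring). This is the same kind of change as before, though the place is not identical: in the earlier pair it sits next to the ring atom that bears an ethyl group, here next to the ring atom that bears a methyl group. Since no change at the digits printed from compound 1 to compound 2 (within the scatter) was flat, compound 4 is expected to show a step of a 1.0-fold higher number from compound 3 to compound 4 (0.02 log units; within the scatter) in this assay. Compound 4 is therefore estimated at 9 nM, between 4 nM and 20 nM.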

Compound 4, half-maximal inhibitory concentration: 25.2 nM
For compound 4 the middle estimate is 2.8-fold (0.45 log units) below the measured one, outside the stated range (above it).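

In this assay, isopropyl in place of cyclohexyl gives a 2.9-fold higher number from compound 3 to compound 4 (0.47 log units; beyond the scatter), so the flat step seen on the core of compound 1 did not carry over to the core of compound 3: the same change on two cores in this assay, no change at the digits printed (within the scatter) from compound 1 to compound 2 and a 2.9-fold higher number (0.47 log units; beyond the scatter) from compound 3 to compound 4, 2.9-fold (0.47 log units) apart, beyond the scatter of two such steps

Hydrogen in place of methyl on a saturated chain carbon bound to a saturated ring carbon gives a 6.3-fold higher number from compound 2 to compound 4 (0.80 log units; beyond the scatter), so this change also depends on its partner group: the same change on two cores in this assay, a 2.2-fold higher number (0.33 log units; beyond the scatter) from compound 1 to compound 3 and a 6.3-fold higher number (0.80 log units; beyond the scatter) from compound 2 to compound 4, 2.9-fold (0.47 log units) apart, beyond the scatter of two such steps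

Both comparisons rest on the same four compounds, so they show one interplay between the two places and do not show its cause or whether it extends to other groups.

As far as these compounds go, it remains open how cyclopentyl or tert-butyl on that nitrogen would behave on either core. From the compounds shown here alone, a propyl group in place of the ethyl is equally open.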